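This account rests on a few compounds, and the source may have more. Where it says the series, first, only, none or still open, it means among the compounds named here.

Measured compounds:
compound 1, `CCNC(=O)c1noc(-c2cc(C(C)C)c(O)cc2O)c1-c1cc(COCC(N)=O)no1`, 97 nM
compound 2, `CCNC(=O)c1noc(-c2cc(C(C)C)c(O)cc2O)c1-c1cc(CN2CCCCC2)no1`, 93 nM
compound 3, `CCNC(=O)c1noc(-c2cc(C(C)C)c(O)cc2O)c1-c1cc(C(=O)OCC)no1`, "not determined" (no result reported)

Compounds 1 and 2 share one core and differ only in the group carried on a saturated chain carbon bound to an aromatic carbon. In a functional assay on HCT-116 cells (Homo sapiens) for inhibition (a higher number here means a weaker inhibitor, a lower number a stronger inhibitor), compound 1 gives 97 nM and compound 2 gives 93 nM; the step of a 1.0-fold lower number from compound 1 to compound 2 (0.02 log units; within the scatter) lies within the scatter, so the two cannot be told apart. Compound 3 carries the same core, but for it no single number is reported in this assay, so it stands nowhere on the scale that compounds 1 and 2 define.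

Compound 4, `CCNC(=O)c1noc(-c2cc(C(C)C)c(O)cc2O)c1-c1cnn(CC)c1`, is not yet measured. It differs from compound 3 in one place: 1-ethyl-1H-pyrazol-4-yl in place of 3-(ethoxycarbonyl)-1,2-oxazol-5-yl on an aromatic carbon. Going by the values given here, the only measured step, from compound 1 to compound 2, concerns a different part of the molecule and was within the scatter, so no measured step bears on this change, and there is no basis for expecting a particular size or direction beyond the scatter. Among the compounds with values here, the only anchors are the numbers of compounds 1 and 2. On that footing compound 4 is expected to give about 150 nM in this assay, with a wide range from 40 nM to 600 nM.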

Compound 4, half-maximal inhibitory concentration: 26 nM
Compound 4: the middle estimate sits 5.8-fold (0.76 log units) above what was measured, outside the stated range (below it).
By their numbers in this assay, from the lowest: compound 4; then compounds 2 and 1 (each within the scatter of the next).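

Compound 3 has no single number in this assay and so the step from it to compound 4 cannot be read. The compounds shown leave open how 1-ethyl-1H-pyrazol-4-yl compares with 3-(ethoxycarbonyl)-1,2-oxazol-5-yl on the shared core. No evidence shown here bears on the value of compound 4.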